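A few compounds are considered here, and "the series" means these few. Any claim that something is new, unique, unknown or untested is made for them only; others in the source may bear on it.

Of the compounds shown here, three sharing one core have been tested in an ADME assay on HepG2 cells (Homo sapiens) for cytotoxicity, read by MTT assay, with a stated time of 48 h; on this read-out lower numbers stand for stronger inhibition and higher numbers for weaker inhibition. Compound 1 `O=S(=O)(c1ccc(-c2ccc3ncnc(Nc4ccc(OCc5cccc(F)c5)c(Cl)c4)c3c2)cc1)N1CCCC1` gives only a limit, > 15000 nM. Compound 2 `CN1CCCN(S(=O)(=O)c2ccc(-c3ccc4ncnc(Nc5ccc(OCc6cccc(F)c6)c(Cl)c5)c4c3)cc2)CC1` gives a true number, 1810 nM. Compound 3 `O=S(=O)(c1ccc(-c2ccc3ncnc(Nc4ccc(OCc5cccc(Cl)c5)c(Cl)c4)c3c2)cc1)N1CCOCC1` also gives only a limit, > 15000 nM. Compound 3 therefore sits at the limit of > 15000 nM in this assay, at which 2 of the 3 values shown sit, with no exact number to start from.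

Compound 4 `O=S(=O)(c1ccc(-c2ccc3ncnc(Nc4ccc(OCc5ccc(C(F)(F)F)c(F)c5)c(Cl)c4)c3c2)cc1)N1CCOCC1` keeps the group on the sulfonyl sulfur of compound 3 and has 3-fluoro-4-(trifluoromethyl)phenyl in place of 3-chlorophenyl, on a saturated chain carbon bound to an oxygen on an aromatic ring: 3-fluoro-4-(trifluoromethyl)phenyl in place of 3-chlorophenyl on a saturated chain carbon bound to an oxygen on an aromatic ring.

For the measured compounds named here, the only measured step is an at least 8.2-fold lower number from compound 1 to compound 2 (0.91 log units; beyond the scatter), where 4-methyl-1,4-diazepan-1-yl replaces pyrrolidin-1-yl on a sulfonyl sulfur. Going by the values given here, that step lies at a different place in the molecule, so it offers no direct guide here, and no measured step covers this change. No step beyond the scatter is therefore expected, and a further limit is the likeliest report.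

The expected change is a step that the limit leaves unreadable from compound 3 to compound 4. For compound 4 the estimate is 20000 nM, with an expected range from 7000 nM to 50000 nM.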

Compound 4, half-maximal inhibitory concentration: > 15000 nM
Compound 4 ended at the assay's limit; the forecaster's own chance of this, stated with the estimate: 75%; the middle value does not contradict the limit.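

Compound 3 and compound 4 both end at a limit of the assay rather than at a number, so no step can be read between them: the limit of > 15000 nM in this assay, at which 3 of the 4 values shown sit.

The compounds shown leave open whether 3-fluoro-4-(trifluoromethyl)phenyl in place of 3-chlorophenyl changes the true value at all.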